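Trading propylcarbonyl for acetyl in compound 2

A few compounds are considered here, and "the series" means these few. Any claim that something is new, unique, unknown or untested is made for them only; others in the source may bear on it.

Of the compounds shown here, three have been measured in a functional assay on SW-620 cells (Homo sapiens) for antiproliferative activity, read by sulforhodamine B assay, with a stated time of 72 h; on this read-out lower numbers stand for stronger inhibition and higher numbers for weaker inhibition. Compound 1 `COc1cc(/C=C/COC(C)=O)ccc1OC(C)=O` gives 360 nM, compound 2 `CCCC(=O)OC/C=C/c1ccc(OC(=O)CCC)c(OC)c1` gives 7850 nM, and compound 3 `CCC(=O)OC/C=C/c1ccc(OC(=O)CC)c(OC)c1` gives 47400 nM. Compound 2 therefore has the second highest of the three numbers, and its gaps to the other two lie beyond the usual scatter. The three do not fall into a simple order by chain length, and compound 3 is the one that breaks it.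

Compound 4 `CCCC(=O)OC/C=C/c1ccc(OC(C)=O)c(OC)c1` has not yet been measured. It differs from compound 2 in one place: hydrogen in place of ethyl on a saturated chain carbon bound to a carbonyl carbon, which also reads as propylcarbonyl to acetyl. Among the compounds with values here, no measured pair isolates this change, so the expectation is loose. Acetyl also appears in compound 1 at 360 nM, which points towards a lower number. In this assay the expected move is a 3.9-fold lower number from compound 2 to compound 4 (0.59 log units; beyond the scatter), a step towards stronger inhibition and beyond the scatter. The estimated value for compound 4 is 2000 nM, with an expected range of 400 nM to 10000 nM.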

Compound 4, half-maximal inhibitory concentration: 10200 nM
For compound 4 the middle estimate is 5.1-fold (0.71 log units) below the measured one; the measured number lies above the stated range.
By their numbers in this assay, from the lowest: compound 1; then compounds 2 and 4 (each within the scatter of the next); then compound 3.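

In this assay, acetyl in place of propylcarbonyl at this place makes no difference that can be told from scatter, with a 1.3-fold higher number from compound 2 to compound 4 (0.11 log units; within the scatter). The place that compound 4 leaves unchanged behaves quite differently: propylcarbonyl there in place of the acetyl of compound 1 gives the large step of a 28-fold higher number from compound 1 to compound 4 (1.45 log units; beyond the scatter). The low number of compound 1 therefore does not follow from acetyl at the place changed here alone, and within this pair of steps the weight falls on the other acyl group.

No measurement shown bears on why the two places respond so differently. Also open, on these data alone, is how either place would respond to a longer chain such as pentylcarbonyl, to a benzoyl group, or to a free hydroxyl group in place of the acyl group.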